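Swapping the amine side chain of a weak inhibitor

A few compounds are considered here, and "the series" means these few. Any claim that something is new, unique, unknown or untested is made for them only; others in the source may bear on it.

Compound 3 `CCN(Cc1ccccn1)c1cccc(C(=O)N2CCc3ccc(OS(N)(=O)=O)cc3C2)c1` shares its core with compound 1 `CCN(Cc1ccc(F)cc1)c1cccc(C(=O)N2CCc3ccc(OS(N)(=O)=O)cc3C2)c1` and compound 2 `CCN(Cc1cccc(Br)c1)c1cccc(C(=O)N2CCc3ccc(OS(N)(=O)=O)cc3C2)c1`. In an assay on HEK293 cells for inhibition of Steryl-sulfatase (Homo sapiens), tested at 0.1 uM (a higher number here means a stronger effect of the compound at the concentration tested, a lower number a weaker effect), compound 3 gives 6.5%, the lowest of the three numbers; compound 1 gives 10.9% and compound 2 gives 20.9%. The measured steps were a number 4.4 percentage points lower from compound 1 to compound 3 (within the scatter), a number 10 percentage points higher from compound 1 to compound 2 (within the scatter) and a number 14.4 percentage points lower from compound 2 to compound 3 (beyond the scatter). Compound 4 `CN(CCN1CCCCC1)c1cccc(C(=O)N2CCc3ccc(OS(N)(=O)=O)cc3C2)c1` differs from compound 3 on the aromatic carbon: methyl(2-(piperidin-1-yl)ethyl)amino in place of ethyl((pyridin-2-yl)methyl)amino on an aromatic carbon. Within the data shown here, none of the measured steps bears directly on this change, since each of them only exchanged the ring on the saturated carbon, and even the largest was modest. For compound 4 no step beyond the scatter is therefore expected, a number 3.5 percentage points higher from compound 3 to compound 4 (within the scatter). Compound 4 is estimated at 10%, within 0% to 28%.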

Compound 4, a percentage reported as inhibition, at one concentration (the size of the read-out at that concentration, not a potency): 24.5%
The estimate for compound 4 lay 14.5 percentage points below the measured number, and the stated range covers the measured number.
By their numbers in this assay, from the lowest: compounds 3, 1, 2 and 4 (each within the scatter of the next, the first and the last beyond it).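

The aromatic carbon carrying the side chain accepts a non-aromatic ring: methyl(2-(piperidin-1-yl)ethyl)amino gives a number 3.6 percentage points higher from compound 2 to compound 4 (within the scatter) yet also a number 18 percentage points higher from compound 3 to compound 4 (beyond the scatter) and a number 13.6 percentage points higher from compound 1 to compound 4 (beyond the scatter) in this series. A side chain with no aromatic ring can therefore match the best of the benzyl-type chains shown, with the same count of heavy atoms. Nothing available here explains why the number moves.

Going by these compounds, the ring, the chain and the small alkyl group on the nitrogen all differ at once, so which of them counts stays open. A morpholine ring or a dimethylamino group at the chain end, or a longer chain, would help to separate them.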